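From propylamino to pentyloxy at the assay's limit

A few compounds are considered here, and "the series" means these few. Any claim that something is new, unique, unknown or untested is made for them only; others in the source may bear on it.

Three compounds share a core and differ in one group on it. In an ADME assay on HFF cells (Homo sapiens) for cytotoxicity, with a stated time of 8 days (a higher number here means that more compound is tolerated, a lower number that less compound is tolerated), compound 1 `CCOc1nc(N)nc2c1ncn2/C=C1/CC1(CO)CO` gives > 300000 nM, which is a limit and not a number. Compound 2 `Nc1nc(N2CCCC2)c2ncn(/C=C3/CC3(CO)CO)c2n1` gives > 300000 nM, also a limit. Compound 3 `CCCNc1nc(N)nc2c1ncn2/C=C1/CC1(CO)CO` gives > 300000 nM, again a limit. So compound 3 stands where the others do, and what they share is the limit of > 300000 nM in this assay, at which 3 of the 3 values shown sit.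

Compound 4 `CCCCCOc1nc(N)nc2c1ncn2/C=C1/CC1(CO)CO` has pentyloxy in place of propylamino on an aromatic carbon, the same place where the three measured compounds vary: pentyloxy in place of propylamino on an aromatic carbon.

The most closely related measured change is a step that the two limits leave unreadable from compound 1 to compound 3, since it also swaps propylamino and an oxygen-linked chain. The other two, a step that the two limits leave unreadable from compound 1 to compound 2 and a step that the two limits leave unreadable from compound 2 to compound 3, add no size either. Within the data shown here, no measured step therefore sets a size for this change, and no number has yet appeared in this assay. Compound 4 may well report only a limit too. Allowing for its longer chain, a modest downward move is the cautious expectation, and the estimate is an at least 1.3-fold lower number from compound 3 to compound 4 (0.13 log units; that floor lies within the scatter). For compound 4 the expected value is 220000 nM, with an estimated range of 70000 nM to 300000 nM.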

Compound 4, half-maximal cytotoxic concentration: 259000 nM
Compound 4: the middle estimate sits 1.2-fold (0.07 log units) below what was measured; the measured number falls inside the stated range.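

In this assay, among these compounds, compound 4 gives 259000 nM, the first real number for any group at this position on the shared core. Compounds 1, 2 and 3 each report only a limit, so the steps among them cannot be read, and they mark a common ceiling: the limit of > 300000 nM in this assay, at which 3 of the 4 values shown sit.

Measured against that ceiling, the change yields floors rather than full sizes: an at least 1.1-fold lower number from compound 3 to compound 4 (0.06 log units; that floor lies within the scatter) for pentyloxy in place of propylamino, an at least 1.1-fold lower number from compound 2 to compound 4 (0.06 log units; that floor lies within the scatter) for pentyloxy in place of pyrrolidin-1-yl, and an at least 1.1-fold lower number from compound 1 to compound 4 (0.06 log units; that floor lies within the scatter) for the pentyloxy chain in place of ethoxy.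

The compounds shown leave open how large any of these steps really is, and whether a chain longer than pentyloxy, such as octyloxy, would give a number clearly lower than that of compound 4. They also do not tell whether a carboxylic acid or a benzylamino group at this place would give a number or only another limit.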